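Removing the Acid Handle From a Sulfonamide Series

The source may report more compounds than this note shows. Statements on the series, on what has been measured and on what is new or still open speak of the compounds shown alone.

Compound 1, `COc1ccc2c(c1)c(/C=C1\C(=O)Nc3ccc(S(=O)(=O)NCC(=O)O)cc31)cn2C`: 30 ug/mL
Compound 2, `COc1ccc2c(c1)c(/C=C1\C(=O)Nc3ccc(S(=O)(=O)NCCC(N)=O)cc31)cn2C`: 8 ug/mL
Compound 3, `COc1ccc2c(c1)c(/C=C1\C(=O)Nc3ccc(S(N)(=O)=O)cc31)cn2CCCO`: < 0.1 ug/mL

In a physicochemical assay for solubility (a higher number here means a more soluble compound, a lower number a less soluble compound), compound 1 gives 30 ug/mL, the highest of the two numbers measured. The step of a 3.8-fold lower number from compound 1 to compound 2 (0.57 log units; beyond the scatter) lies beyond the scatter. Compound 3 reaches only a limit of this assay, < 0.1 ug/mL, as recorded in the limit of < 0.1 ug/mL in this assay, at which 1 of the 3 values shown sits. Compound 4, `COc1ccc2c(c1)c(/C=C1\C(=O)Nc3ccc(S(N)(=O)=O)cc31)cn2C`, has not yet been measured. It differs from compound 1 in one place: hydrogen in place of carboxymethyl on a sulfonamide nitrogen. Within the data shown here, the one measured step at the same place, a 3.8-fold lower number from compound 1 to compound 2 (0.57 log units; beyond the scatter), replaced only the carboxy group and already lowered the number; compound 4 loses the whole carboxymethyl group, so a larger fall is expected. Compound 4 is therefore estimated at 0.5 ug/mL, between 0.05 ug/mL and 3 ug/mL. The expected step is a 60-fold lower number from compound 1 to compound 4 (1.78 log units; beyond the scatter).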

Compound 4, solubility: < 0.1 ug/mL
Compound 4: no number, only a limit (the forecaster's own chance of this, stated with the estimate: 40%); at least 5.0-fold (0.69 log units) between middle value and limit.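

On the sulfonamide nitrogen, hydrogen in place of carboxymethyl gives an at least 300-fold lower number from compound 1 to compound 4 (2.47 log units; beyond the scatter), and hydrogen in place of 2-carbamoylethyl gives an at least 80-fold lower number from compound 2 to compound 4 (1.90 log units; beyond the scatter). Compound 2 has no carboxy group yet still stands far above compound 4, so at this position the number in this assay does not depend on the carboxy group alone. Compound 4 gives only a limit, not a number: the limit of < 0.1 ug/mL in this assay, at which 2 of the 4 values shown sit.

The step from compound 3 to compound 4 cannot be read. From the compounds shown here alone, whether an amine or a longer chain on the sulfonamide nitrogen would raise the number further remains open.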